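The source may report more compounds than this note shows. Statements on the series, on what has been measured and on what is new or still open speak of the compounds shown alone.

Measured compounds in a functional assay on HeLa cells (Homo sapiens) for antiproliferative activity, read by CCK-8 assay, with a stated time of 48 h; on this read-out higher numbers stand for weaker inhibition and lower numbers for stronger inhibition:
compound 1 `COc1ccc(/C=C\c2cc(OC)c(OC)c(OC)c2)cc1OCc1ccc(CN2CC[C@@H](C(=O)O)C2)cc1`: 12800 nM
compound 2 `COc1ccc(/C=C\c2cc(OC)c(OC)c(OC)c2)cc1OCc1ccc(CNCCNC(C)=O)cc1`: 6400 nM

Among the measured compounds shown here, compound 2 stands on the lower of the two numbers, but its only neighbour is compound 1, and the step of a 2.0-fold lower number from compound 1 to compound 2 (0.30 log units; within the scatter) does not separate them. On these two numbers compound 2 and compound 1 cannot be told apart.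

Compound 3 `COc1ccc(/C=C\c2cc(OC)c(OC)c(OC)c2)cc1OCc1ccc(CN2CCCC[C@@H]2C(=O)O)cc1` has not been measured. It differs from compound 2 at one place: 2-carboxypiperidin-1-yl in place of (2-acetamidoethyl)amino on a saturated chain carbon bound to an aromatic carbon. The change brings a saturated nitrogen ring carrying a carboxylic acid back onto the saturated chain carbon bound to an aromatic carbon, a motif compound 1 also carries, though with a different ring and a different position of the acid. For the measured compounds named here, the only measured step that bears on it is a 2.0-fold lower number from compound 1 to compound 2 (0.30 log units; within the scatter), which removed such a ring acid in favour of the (2-acetamidoethyl)amino group and stayed within the scatter. Nothing beyond the scatter is therefore expected in this assay from the reverse kind of change.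

The step to compound 3 is expected to be a 1.6-fold higher number from compound 2 to compound 3 (0.19 log units; within the scatter), a shift within the scatter. For compound 3 the estimate is 10000 nM, with a range from 3500 nM to 30000 nM.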

Compound 3, half-maximal inhibitory concentration: > 10000 nM
Compound 3 gave a limit, no number; the forecaster's own chance of this, stated with the estimate: 10%; the middle value sits exactly at the limit.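

In this assay compound 3 gives > 10000 nM, which is a limit of the assay and not a number, so the 2-carboxypiperidin-1-yl group on the saturated chain carbon bound to an aromatic carbon adds a limit rather than a third readable value to the series: the limit of > 10000 nM in this assay, at which 1 of the 3 values shown sits.

The replacement of (2-acetamidoethyl)amino by 2-carboxypiperidin-1-yl can be read only as a floor, an at least 1.5-fold higher number from compound 2 to compound 3 (0.19 log units; that floor lies within the scatter), so this change has a lower bound on its size but no measured size, and that bound does not establish a change beyond the scatter. The step between the two ring acids, 3-carboxypyrrolidin-1-yl and 2-carboxypiperidin-1-yl, cannot be read, so ring size and the position of the acid remain unresolved at this place.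

The compounds shown leave open whether the carboxylic acid or the saturated nitrogen ring carries any effect of the change, a question that a plain piperidin-1-yl group or a methyl ester of the 2-carboxypiperidin-1-yl group could address. They also leave open how a chain longer than (2-acetamidoethyl)amino, or a simple primary amine, would read at this place in this assay.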